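The compounds below may be only part of what the source reports. "The series", "measured", "known", "first", "only" and "open" are said of these compounds alone.

Working notes on the series. Three analogues share one core and differ only in the substituent on the phenol ring: compound 1 `O=C(c1cccnc1)c1cc(Cl)ccc1O` carries chloro, compound 2 `O=C(c1cccnc1)c1cc(F)ccc1O` fluoro and compound 3 `O=C(c1cccnc1)c1cc(Br)ccc1O` bromo. In a functional assay on IMR-32 cells (Homo sapiens) for cytotoxicity, read by sulforhodamine B assay, with a stated time of 48 h (on this read-out higher numbers stand for weaker inhibition and lower numbers for stronger inhibition), compound 1 gives 19500 nM, compound 2 gives 6210 nM and compound 3 gives 23400 nM. Compound 3 has the highest number of the three; the nearest step to it is a 1.2-fold higher number from compound 1 to compound 3 (0.08 log units; within the scatter), so these two cannot be ordered, and the furthest is a 3.8-fold higher number from compound 2 to compound 3 (0.58 log units; beyond the scatter). Compound 4 `Cc1ccc(O)c(C(=O)c2cccnc2)c1` has not been measured. The change is methyl in place of bromo on an aromatic carbon. The measured steps exchange one halogen for another: a 3.1-fold lower number from compound 1 to compound 2 (0.50 log units; beyond the scatter) and a 3.8-fold higher number from compound 2 to compound 3 (0.58 log units; beyond the scatter) are modest, while a 1.2-fold higher number from compound 1 to compound 3 (0.08 log units; within the scatter) lies within the scatter. None of them involves methyl, so they show only that chloro and bromo give matching numbers and fluoro a lower one. The step in this assay is therefore expected to be a 1.3-fold lower number from compound 3 to compound 4 (0.11 log units; within the scatter), with no direction supported beyond the scatter. Compound 4 is estimated at 18000 nM, in the range 7000 nM to 45000 nM.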

Compound 4, half-maximal inhibitory concentration: 5540 nM
Beside the measured number, compound 4's estimate is 3.2-fold (0.51 log units) above it; the measured number lies below the stated range.
By their numbers in this assay, from the lowest: compounds 4 and 2 (each within the scatter of the next); then compounds 1 and 3 (each within the scatter of the next).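

Working from this assay, methyl on the aromatic carbon para to the hydroxy group separates from bromo and chloro, with a 4.2-fold lower number from compound 3 to compound 4 (0.63 log units; beyond the scatter) and a 3.5-fold lower number from compound 1 to compound 4 (0.55 log units; beyond the scatter). Against fluoro there is a 1.1-fold lower number from compound 2 to compound 4 (0.05 log units; within the scatter), so methyl and fluoro cannot be ordered and the compounds fall into two groups: compounds 2 and 4 with the lower numbers, compounds 1 and 3 with the higher. The split therefore does not run between halogens and a non-halogen, and nothing available bears on why the substituents group this way.

Open, from the compounds shown here alone, is how an amine, a carboxylic acid or a longer chain such as propyl at this same carbon would compare with these two groups. Also open, going by these compounds, is whether a number clearly lower than those of compounds 2 and 4 can be reached here at all.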